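A few compounds are considered here, and "the series" means these few. Any claim that something is new, unique, unknown or untested is made for them only; others in the source may bear on it.

Compound 1 `Clc1ccc(Cn2cc(COc3ccccc3)nn2)cc1` and compound 2 `Brc1ccc(Cn2cc(COc3ccccc3)nn2)cc1` share one core and differ at a single point, (bromo in place of chloro on an aromatic carbon). In an ADME assay on PANC-1 cells (Homo sapiens) for inhibition, read by MTT assay, with a stated time of 48 h (on this read-out lower numbers stand for stronger inhibition of growth and higher numbers for weaker inhibition of growth), compound 1 gives a value that is a limit of the assay, > 100 ug/mL. In this assay compound 2 likewise sits at a limit of the assay, > 100 ug/mL. The step that the two limits leave unreadable from compound 1 to compound 2 therefore cannot be read in size. Compound 3 `Clc1ccc(Cn2cc(COc3c(Cl)cc(Cl)cc3Cl)nn2)cc1` carries a different core; the difference between the two cores is not broken down here. In this assay compound 3 also stops at a limit of the assay, > 100 ug/mL. All three values rest on (the limit of > 100 ug/mL in this assay, at which 3 of the 3 values shown sit), so no growth inhibition has been pinned to a number for any of them. Compound 4 `Clc1cc(Cl)c(OCc2cn(Cc3ccc(Br)cc3)nn2)c(Cl)c1` differs from compound 3 by the same change, (bromo in place of chloro on an aromatic carbon). The expected step is estimated as a step that the limit leaves unreadable from compound 3 to compound 4, which rests on compound 3 showing > 100 ug/mL and on a step that the two limits leave unreadable from compound 1 to compound 2 being unreadable. Compound 4 is expected to give about 150 ug/mL, with a likely range from 60 ug/mL to 400 ug/mL, and most probably another limit.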

Compound 4, concentration for 50% growth inhibition: > 100 ug/mL
Compound 4: only a limit was reported (the forecaster's own chance of this, stated with the estimate: 85%); the middle value lies beyond the limit too.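

No new step can be read between compound 3 and compound 4, since both stop at a limit in this assay: the limit of > 100 ug/mL in this assay, at which 4 of the 4 values shown sit.

The compounds shown leave open whether 4-bromobenzyl in place of 4-chlorobenzyl alters growth inhibition in either pair, and at what concentration, if any, each of the four compounds would reach the measured inhibition.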